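This account rests on a few compounds, and the source may have more. Where it says the series, first, only, none or still open, it means among the compounds named here.

Measured so far:
compound 1 `CN1CCN(C[C@H]2CN(c3ccc(-n4cc(-c5ccccn5)cn4)c(F)c3)C(=O)O2)CC1` — 70 ug/mL
compound 2 `O=C1CNC(=O)N1C[C@H]1CN(c2ccc(-n3cc(-c4ccccn4)cn3)c(F)c2)C(=O)O1` — a limit of the assay, > 400 ug/mL
compound 3 `O=C1O[C@@H](Cn2ccnc2)CN1c1ccc(-n2cc(-c3ccccn3)cn2)c(F)c1` — 350 ug/mL

Within the data shown here, in an ADME assay on L02 cells (Homo sapiens) for cytotoxicity, read by MTT assay, with a stated time of 48 h (a lower number here means a stronger inhibitor, a higher number a weaker inhibitor), compound 3 holds the highest of the two numbers; compound 1 is the only other plain number, and the step of a 5.0-fold higher number from compound 1 to compound 3 (0.70 log units; beyond the scatter) is modest. Compound 2 gives a limit and no number, > 400 ug/mL. The step of an at least 1.1-fold lower number from compound 2 to compound 3 (0.05 log units; that floor lies within the scatter) does not separate the two.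

Compound 4 `O=C1O[C@@H](CSc2cccs2)CN1c1ccc(-n2cc(-c3ccccn3)cn2)c(F)c1` differs from compound 3 by (thiophen-2-yl)sulfanyl in place of 1H-imidazol-1-yl on a saturated chain carbon bound to a saturated ring carbon. No measured step swaps in a sulfur-linked ring, so nothing shown anchors this change; only compound 2 with its limit of > 400 ug/mL in this assay, at which 1 of the 3 values shown sits, hints at how high such numbers can run. The expected step of a 1.4-fold lower number from compound 3 to compound 4 (0.15 log units; within the scatter) is none beyond the scatter. Compound 4 is estimated at 250 ug/mL, within 80 ug/mL to 400 ug/mL.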

Compound 4, half-maximal inhibitory concentration: > 400 ug/mL
Compound 4: only a limit was reported (the forecaster's own chance of this, stated with the estimate: 25%); middle value at least 1.6-fold (0.20 log units) away from the limit.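

In this assay compound 4 gives only a limit of the assay, as compound 2 does, so the step between them cannot be read: the limit of > 400 ug/mL in this assay, at which 2 of the 4 values shown sit.

Swapping the imidazole for the sulfur-linked thiophene leaves no resolved change, with an at least 1.1-fold higher number from compound 3 to compound 4 (0.05 log units; that floor lies within the scatter). With an at least 5.7-fold higher number from compound 1 to compound 4 (0.75 log units; beyond the scatter), a third group now stands apart from the 4-methylpiperazin-1-yl of compound 1, which alone gives the lowest number here.

Still open, on these data alone, is whether that lower number needs the whole 4-methylpiperazin-1-yl ring. A morpholine ring or a simple open-chain amine at this place would help test that.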